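The compounds below may be only part of what the source reports. "The series", "measured", "known", "first", "only" and "open" are said of these compounds alone.

Measured in a functional assay on Ehrlich cells (Mus musculus) for cytotoxicity, read by LDH release, with a stated time of 48 h; a lower number here means a stronger inhibitor, a higher number a weaker inhibitor:
- compound 1 `Cc1cc(C(=O)c2ccccc2)ccc1OCC(=O)Nc1nc(-c2ccccc2)cs1`: 24500 nM
- compound 2 `COc1ccc(-c2csc(NC(=O)COc3ccc(C(=O)c4ccccc4)cc3C)n2)cc1`: 28600 nM

Going by the values given here, compound 1 and compound 2 lie within the scatter of each other, so compound 1 does not stand apart from the only other measured compound. Compound 3 `Cc1cc(C(=O)c2ccc(F)cc2)ccc1OCC(=O)Nc1nc(-c2ccccc2)cs1` is not yet measured in this assay. It differs from compound 1 as follows: fluoro in place of hydrogen on an aromatic carbon. This is fluoro in place of hydrogen on an aromatic carbon, or phenyl to 4-fluorophenyl. Among the compounds with values here, one measured step bears on it, and only loosely: a 1.2-fold higher number from compound 1 to compound 2 (0.07 log units; within the scatter). That step brings in methoxy rather than fluoro, and at a different place in the structure. Within the data shown here, the data hold no measured fluoro step. The expected step is a 1.0-fold lower number from compound 1 to compound 3 (0.01 log units; within the scatter), with no change beyond the scatter anticipated. For compound 3 the estimated value is 24000 nM, with an expected range of 12000 nM to 45000 nM.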

Compound 3, half-maximal inhibitory concentration: 38600 nM
Estimate against measurement, compound 3: 1.6-fold (0.21 log units) below; low and high end bracket the measured number.
By their numbers in this assay, from the lowest: compounds 1, 2 and 3 (each within the scatter of the next).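

In this assay, phenyl to 4-fluorophenyl on the benzoyl end gives a 1.6-fold higher number from compound 1 to compound 3 (0.20 log units; within the scatter) for this single fluoro, placed para to a large group. Going by these compounds alone, the only earlier step, methoxy in place of hydrogen, lies elsewhere in the structure, so this is the first reading at this position, and here one fluoro atom leaves the number within the scatter of compound 1. No evidence on the cause or on any property of this change is available.

Still open, as far as these compounds go, is whether an amine or a carboxylic acid on this same aromatic carbon would move the number beyond the scatter. Also open, from the compounds shown here alone, is how fluoro would read at the place that carries methoxy in compound 2, and whether chloro at either place would read differently.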